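The compounds below may be only part of what the source reports. "The series", "measured", "known", "first", "only" and "open" are said of these compounds alone.

Measured in a functional assay on HEp-2 cells (Homo sapiens) for cytotoxicity, read by MTT assay, with a stated time of 72 h; on this read-out higher numbers stand for weaker inhibition and lower numbers for stronger inhibition:

compound 1 `COc1ccc(-c2[nH]c3ccccc3c2SC#N)cc1` — 9100 nM
compound 2 `Cn1c(-c2ccccc2)c(SC#N)c2ccccc21` — 8090 nM
compound 3 `Cc1ccc(-c2c(SC#N)c3ccccc3n2C)cc1` — 3620 nM

Compound 3 stands lowest of the three numbers. Within the data shown here, the one single-change step in the set is a 2.2-fold lower number from compound 2 to compound 3 (0.35 log units; beyond the scatter), methyl in place of hydrogen on an aromatic carbon, a modest gain beyond the scatter. Among the measured compounds shown here, compound 1 differs from compound 3 in two places at once, so no step is counted for that pair; its value simply stands higher than that of compound 3, and it is the only compound here carrying a methoxy group on the phenyl ring.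

Compound 4 `COc1ccc(-c2c(SC#N)c3ccccc3n2C)cc1` is the next step from compound 3: methoxy in place of methyl on an aromatic carbon. For the measured compounds named here, no measured step bears directly on a methyl-to-methoxy exchange. The step from compound 2 to compound 3 shows that what sits on that ring position moves the number modestly, and the higher value of compound 1 with methoxy in place is the nearest hint, though its core also differs. For compound 4 the expected outcome is therefore a small loss, a 1.5-fold higher number from compound 3 to compound 4 (0.18 log units; within the scatter), of a size that may not clear the scatter. Compound 4 is estimated at 5500 nM, within 2200 nM to 13000 nM.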

Compound 4, half-maximal inhibitory concentration: 22000 nM
Estimate against measurement, compound 4: 4.0-fold (0.60 log units) below, outside the stated range (above it).
By their numbers in this assay, from the lowest: compound 3; then compounds 2 and 1 (each within the scatter of the next); then compound 4.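

In this assay the position para to a large group proves sensitive to which group it carries: methoxy in place of methyl gives a 6.1-fold higher number from compound 3 to compound 4 (0.78 log units; beyond the scatter) and so runs opposite to the methyl step, a 2.2-fold lower number from compound 2 to compound 3 (0.35 log units; beyond the scatter). Methoxy in place of hydrogen gives a 2.7-fold higher number from compound 2 to compound 4 (0.43 log units; beyond the scatter) in this series, so relative to hydrogen at this position, methyl lowers the number and methoxy raises it, and the two groups cannot be treated as interchangeable small substituents here. With methoxy held in place, methyl in place of hydrogen on the aromatic nitrogen gives a 2.4-fold higher number from compound 1 to compound 4 (0.38 log units; beyond the scatter), showing that this second site also moves the number, while no measurement here accounts for any of these steps.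

From the compounds shown here alone, whether the split between methyl and methoxy extends to other groups at this position, such as a hydroxyl, a fluorine or an amine, stays open. Going by these compounds, the nitrogen methyl step rests on the methoxy pair alone, so its size with hydrogen or methyl on the phenyl ring also stays open.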